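The source may report more compounds than this note shows. Statements on the series, on what has been measured and on what is new or still open speak of the compounds shown alone.

Compounds measured so far in a functional assay on NUGC-3 cells (Homo sapiens) for cytotoxicity, read by sulforhodamine B assay, with a stated time of 72 h; a lower number here means a stronger inhibitor of growth, a higher number a weaker inhibitor of growth:

Compound 1 `O=C(Nc1ccccc1O)C1CCc2ccccc2N1C(=O)c1ccccc1` gives 3780 nM.
Compound 2 `O=C(Nc1ccccc1O)C1CCc2ccccc2N1` gives 2680 nM.
Compound 3 `O=C(Nc1cc(C(F)(F)F)cc(C(F)(F)F)c1)C1CCc2ccccc2N1` gives 8760 nM.

Compound 1 and compound 2 share one core and differ at a single place: benzoyl in place of hydrogen on a nitrogen on an aromatic ring in a ring. The step this change made in this assay is a 1.4-fold higher number from compound 2 to compound 1 (0.15 log units; within the scatter), so the two values cannot be told apart by order. Compound 3 carries a different aryl amide partner; the difference between its core and that of compound 2 is not broken down here. Its value is the highest of the three, and both of its steps to the others are beyond the scatter, so compound 3 is the weakest inhibitor of growth among the measured compounds.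

Compound 4 `O=C(Nc1cc(C(F)(F)F)cc(C(F)(F)F)c1)C1CCc2ccccc2N1C(=O)c1ccccc1` has not yet been measured. It differs from compound 3 in exactly one place: benzoyl in place of hydrogen on a nitrogen on an aromatic ring in a ring. For the measured compounds named here, this is the same change as the one between compound 2 and compound 1, made at the same place of the same kind of ring system, on the core of compound 3 instead.

Because the earlier step was a 1.4-fold higher number from compound 2 to compound 1 (0.15 log units; within the scatter), the step from compound 3 to compound 4 in this assay is expected to be of a similar, small size, a 1.3-fold higher number from compound 3 to compound 4 (0.12 log units; within the scatter). Going by the values given here, only one earlier example of the change exists, on a different amide partner, so the expectation is held loosely. On that basis compound 4 is estimated at 11500 nM in this assay, likely between 5000 nM and 26000 nM.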

Compound 4, concentration for 50% growth inhibition: 1680 nM
Beside the measured number, compound 4's estimate is 6.8-fold (0.84 log units) above it; the whole stated range lies above it.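

In this assay, benzoyl in place of hydrogen on the nitrogen of the ring gives a 5.2-fold lower number from compound 3 to compound 4 (0.72 log units; beyond the scatter), so on this core the change brings a real gain in growth inhibition, and compound 4 stands well clear of its parent. Set beside the earlier pair, the change does not carry a single size from one core to the other in this series: the same change on two cores in this assay, a 1.4-fold higher number (0.15 log units; within the scatter) from compound 2 to compound 1 and a 5.2-fold lower number (0.72 log units; beyond the scatter) from compound 3 to compound 4, 7.4-fold (0.87 log units) apart, beyond the scatter of two such steps The two pairs show that the outcome of this change depends on the core it is made on, but they do not show which part of the amide partner sets that outcome, as the two partners differ as whole groups, and two pairs give no rule for any third core.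

The compounds shown leave open whether the gain belongs to benzoyl itself or would also appear with a smaller acyl group such as acetyl, or with a longer chain on the same nitrogen. For the compounds shown here, they also leave open how the change would behave on an amide partner carrying only one trifluoromethyl group, or an amine or a carboxylic acid in place of the groups seen so far.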